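Urea to amide: compound 3 on UACC-62 cells

The compounds below may be only part of what the source reports. "The series", "measured", "known", "first", "only" and "open" are said of these compounds alone.

Measured compounds:
compound 1 `O=C(Nc1cccc(-n2cc(-c3ccncc3)c(-c3cc(O)cc(Cl)c3)n2)c1)Nc1ccc(Cl)c(C(F)(F)F)c1` — 104%
compound 2 `COc1cc(Cl)cc(-c2nn(-c3cccc(NC(=O)Nc4ccc(Cl)c(C(F)(F)F)c4)c3)cc2-c2ccncc2)c1` — 95%

In a functional assay on UACC-62 cells (Homo sapiens) for inhibition, read by sulforhodamine B assay, with a stated time of 48 h, tested at 0.01 uM (on this read-out lower numbers stand for a stronger effect and higher numbers for a weaker effect at the one concentration tested), compound 1 gives 104% and compound 2 gives 95%. Going by the values given here, on these numbers compound 2 stands together with compound 1: the only measured step, a number 9 percentage points lower from compound 1 to compound 2 (within the scatter), lies within the scatter, so the two compounds are not told apart.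

Compound 3 `COc1cc(Cl)cc(-c2nn(-c3cccc(NC(=O)c4cccc(C(F)(F)F)c4)c3)cc2-c2ccncc2)c1` is not yet measured. It differs from compound 2 by 3-(trifluoromethyl)phenyl in place of (4-chloro-3-(trifluoromethyl)phenyl)amino on a carbonyl carbon. Among the compounds with values here, no measured step touches the carbonyl carbon or its neighbours; the one step on record, a number 9 percentage points lower from compound 1 to compound 2 (within the scatter), concerns only the oxygen on the aromatic ring and gives no guide here. With both measured compounds showing essentially no inhibition at this concentration, compound 3 is expected to stay in the same region, with an expected step of a number 3 percentage points higher from compound 2 to compound 3 (within the scatter) not beyond the scatter. The estimated value for compound 3 is 98%, within the range 84% to 112%.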

Compound 3, a percentage reported as activity, at one concentration (the size of the read-out at that concentration, not a potency): 98%
The estimate for compound 3 equals the measured number at the digits printed, within the range that was stated.
By their numbers in this assay, from the lowest: compounds 2, 3 and 1 (each within the scatter of the next).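

In this assay, going by these compounds alone, the first change at the carbonyl carbon, 3-(trifluoromethyl)phenyl in place of (4-chloro-3-(trifluoromethyl)phenyl)amino, gives a number 3 percentage points higher from compound 2 to compound 3 (within the scatter) and so does not tell the two compounds apart. Within the data shown here, the leaving group carries a nitrogen and a chlorine and the entering group carries neither, yet the urea and the amide stand together on this read-out, and the single step cannot separate the loss of the nitrogen from the loss of the chlorine. Nothing at hand offers an explanation for this result.

As far as these compounds go, it remains open whether any group on this carbonyl carbon would move the number at this single concentration, for example a carboxylic acid or a longer alkyl chain in place of 3-(trifluoromethyl)phenyl. Also open, from the compounds shown here alone, is what an amine on that ring would do.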